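A few compounds are considered here, and "the series" means these few. Any claim that something is new, unique, unknown or untested is made for them only; others in the source may bear on it.

Working notes on the sulfonamide series.

Of the compounds shown here, three have numbers so far. Compound 1 `COc1ccc(Cl)cc1S(=O)(=O)Nc1cncc(-c2cccnc2)c1` gives 73 nM in an assay on isolated protein for inhibition of alkaline phosphatase, tissue-nonspecific isozyme (Homo sapiens); a higher number here means a weaker inhibitor, a lower number a stronger inhibitor. Compound 2 `COc1ccc(OC(F)(F)F)cc1S(=O)(=O)Nc1cncc(C(N)=O)c1` gives 131 nM, and compound 3 `COc1ccc(Br)cc1S(=O)(=O)Nc1cncc(C(N)=O)c1` gives 14 nM. Compound 1 thus sits second highest of the three: its number and that of compound 2 lie within the scatter of each other, while compound 3 stands clearly lower, beyond the scatter. Among the measured compounds shown here, the only single-point step among the measured compounds is a 9.4-fold lower number from compound 2 to compound 3 (0.97 log units; beyond the scatter), a modest change that concerns the substituent on the methoxyphenyl ring and not the aminopyridine side.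

Compound 4 `COc1ccc(Cl)cc1S(=O)(=O)Nc1cncc(C(=O)O)c1` is the next in line. It differs from compound 1 by carboxy in place of pyridin-3-yl on an aromatic carbon, with the change placed two atoms from the ring nitrogen and meta to a large group. For the measured compounds named here, no measured step touches this position, so the expectation rests on the spread of the three numbers rather than on a matching precedent. Compounds 2 and 3 show that a small carbonyl-bearing group at this place is compatible with numbers in the same region as compound 1, so no large shift is assumed. The step from compound 1 to compound 4 is therefore expected to be about a 1.4-fold higher number from compound 1 to compound 4 (0.14 log units; within the scatter), and compound 4 is estimated at 100 nM, with a range from 30 nM to 400 nM.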

Compound 4, half-maximal inhibitory concentration: 134 nM
Compound 4: middle estimate off by 1.3-fold (0.13 log units), on the low side, and the stated range covers the measured number.
By their numbers in this assay, from the lowest: compound 3; then compounds 1, 2 and 4 (each within the scatter of the next).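

Among the compounds shown here, the exchange of pyridin-3-yl for carboxy gives the only step so far at this place, on an aromatic carbon two atoms from the ring nitrogen, and a 1.8-fold higher number from compound 1 to compound 4 (0.26 log units; within the scatter) is how it reads in this assay with the rest of compound 1 held constant. On this one pair, pyridin-3-yl, with 6 heavy atoms and a six-membered aromatic ring, and carboxy, with 3 heavy atoms, no ring and 1 hydrogen-bond donor, are not separated by this read-out, so the place accepts two quite different groups without a step beyond the scatter. No measurement at hand offers an explanation for this result.

From the compounds shown here alone, whether an aminomethyl group, a methyl ester or a longer chain at this place would also stay within the scatter of compound 1 remains open, and one pair cannot show how far this tolerance extends. The compounds shown also offer no pair that differs only in chloro against bromo, so the contribution of that substituent to the numbers at a fixed group on the other side remains unsettled.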